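The source may hold more compounds than are shown below. What is called first, only, known or untested is meant among the compounds shown, and "the series" means these compounds.

Compound 1 `COc1ccc(-c2cnc(NC(=O)c3ccccc3F)n2C)cc1`: in a toxicity assay on THP-1 cells (Homo sapiens) for inhibition (on this read-out higher numbers stand for lower toxicity in this test and lower numbers for higher toxicity in this test), compound 1 gives > 100000 nM, which is a limit of the assay.
Compound 2 `COc1ccc(-c2cnc(NC(=O)C3CCOCC3)n2C)cc1`: in this assay compound 2 gives > 100000 nM, again a limit of the assay.
Compound 3 `COc1ccc(-c2cnc(NC(=O)c3ccccc3Br)n2C)cc1`: in this assay compound 3 gives > 100000 nM, also a limit of the assay.

Compound 3 therefore stands at the same limit as the other two, and none of the three has a readable number. Every step among them is blank: a step that the two limits leave unreadable from compound 1 to compound 2, a step that the two limits leave unreadable from compound 1 to compound 3 and a step that the two limits leave unreadable from compound 2 to compound 3 all fall between two limits, so neither the oxan-4-yl group nor the halogen exchange on the aromatic carbon can be read for size or direction. The only firm point is the limit of > 100000 nM in this assay, at which 3 of the 3 values shown sit, which shows that all three values sit at the same limit.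

Compound 4 `COc1ccc(-c2cnc(NC(=O)c3cnc[nH]3)n2C)cc1` is still to be measured in this assay. It differs from compound 3 by 1H-imidazol-5-yl in place of 2-bromophenyl on a carbonyl carbon. Going by the values given here, no measured step bears on this particular change, since the steps in hand are all unreadable, so no size of effect can be taken from them. Given that every related compound sits at the limit, compound 4 is expected to remain there too, with an estimated step that the limit leaves unreadable from compound 3 to compound 4 that stays within the scatter. The estimate for compound 4 in this assay is 120000 nM, ranging from 40000 nM to 400000 nM.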

Compound 4, half-maximal cytotoxic concentration: > 100000 nM
Compound 4: no number, only a limit (the forecaster's own chance of this, stated with the estimate: 85%); the middle value lies beyond the limit too.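

Compound 4 gives only a limit in this assay, as do compound 1, compound 2 and compound 3, so the steps from those three to compound 4 cannot be read for size or direction: the limit of > 100000 nM in this assay, at which 4 of the 4 values shown sit.

The compounds shown leave open whether any group on the carbonyl carbon would give a readable number in this assay.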